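The source may report more compounds than this note shows. Statements on the series, on what has been measured and on what is new or still open speak of the compounds shown alone.

Of the compounds shown here, three have been measured in an assay for inhibition of ribonucleoside-diphosphate reductase RR1 (Homo sapiens), with a stated time of 30 min; a lower number here means a stronger inhibitor, a higher number a weaker inhibitor. Compound 1 `Oc1ccc(/C=N/NC(=S)Nc2ccccc2)cc1` gives 242000 nM. Compound 2 `Oc1ccc(/C=N/NC(=S)Nc2ccccc2Cl)cc1` gives 46800 nM, and compound 3 `COc1ccccc1NC(=S)N/N=C/c1ccc(O)cc1` gives 41600 nM. Compound 3 thus shows the lowest number of the three, but its gap to compound 2 lies within the scatter, so the two cannot be told apart; only compound 1 stands clearly apart from it. Compound 4 `O=[N+]([O-])c1ccccc1NC(=S)N/N=C/c1ccc(O)cc1` has not yet been measured. It differs from compound 3 by nitro in place of methoxy on an aromatic carbon. Among the measured compounds shown here, no measured step swaps nitro for methoxy. For the measured compounds named here, the steps that bear on it are those that put a group on the same aromatic carbon: a 5.2-fold lower number from compound 1 to compound 2 (0.71 log units; beyond the scatter) and a 5.8-fold lower number from compound 1 to compound 3 (0.76 log units; beyond the scatter) show that either chloro or methoxy there brings a modestly lower number, while a 1.1-fold lower number from compound 2 to compound 3 (0.05 log units; within the scatter) shows that the two groups themselves are not distinguished. Nitro is a third group at the same place, so in this assay a number near that of compound 3 is expected, with no step beyond the scatter in either direction. The expected step is a 1.2-fold lower number from compound 3 to compound 4 (0.08 log units; within the scatter). Compound 4 is therefore estimated at 35000 nM, within a range from 12000 nM to 100000 nM.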

Compound 4, half-maximal inhibitory concentration: 39300 nM
Beside the measured number, compound 4's estimate is 1.1-fold (0.05 log units) below it; measured number inside the range.
By their numbers in this assay, from the lowest: compounds 4, 3 and 2 (each within the scatter of the next); then compound 1.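

In this assay, nitro is a third group on this aromatic carbon, and it gives a 6.2-fold lower number from compound 1 to compound 4 (0.79 log units; beyond the scatter), so all three groups tried here separate clearly from the hydrogen of compound 1. Nitro cannot be told apart from the other two groups, as shown by a 1.1-fold lower number from compound 3 to compound 4 (0.02 log units; within the scatter) and a 1.2-fold lower number from compound 2 to compound 4 (0.08 log units; within the scatter), even though it has more heavy atoms and more hydrogen-bond acceptors than methoxy. Among these compounds, then, having chloro, methoxy or nitro at this place matters, while the choice among the three does not show up in the numbers, and no measurement shown here gives a reason for this.

The compounds shown leave open whether a group of another kind on this carbon, such as an amine, a carboxylic acid or a longer chain, would give a number near those of compound 2, compound 3 and compound 4 or move clearly away from them. They also leave open whether chloro, methoxy or nitro on a different carbon of the same ring would give a similar step from compound 1.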